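This account rests on a few compounds, and the source may have more. Where it says the series, first, only, none or still open, it means among the compounds named here.

Compound 1 `CC1(C)OC(=O)C2(C(=O)O1)C(c1ccc(F)cc1)C(c1ccccc1)=NN2c1ccccc1`: 1470000 nM
Compound 2 `COc1ccc(C2C(c3ccccc3)=NN(c3ccccc3)C23C(=O)OC(C)(C)OC3=O)cc1`: 500000 nM

Both numbers come from a functional assay on aorta (Rattus norvegicus, strain Wistar) for inhibition; a lower number here means a stronger inhibitor, a higher number a weaker inhibitor. Within the data shown here, compound 2 holds the lowest of the two values; the only measured step, a 2.9-fold lower number from compound 1 to compound 2 (0.47 log units; beyond the scatter), separates it from compound 1, and that step is modest.

Compound 3 `CC1(C)OC(=O)C2(C(=O)O1)C(c1cccs1)C(c1ccccc1)=NN2c1ccccc1` has not been measured. Relative to compound 2 it carries thiophen-2-yl in place of 4-methoxyphenyl on a saturated ring carbon. Among the measured compounds shown here, no measured step exchanges the whole group on that saturated ring carbon; the one known step, a 2.9-fold lower number from compound 1 to compound 2 (0.47 log units; beyond the scatter), alters only a substituent on a ring that is itself removed here, so it offers little guidance. With nothing in the data pointing either way, no step beyond the scatter is expected in this assay. The expected step is no change at the digits printed from compound 2 to compound 3 (within the scatter). Compound 3 is therefore estimated at about 500000 nM in this assay, with a range from 170000 nM to 1500000 nM.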

Compound 3, half-maximal inhibitory concentration: 585000 nM
Compound 3: the middle estimate sits 1.2-fold (0.07 log units) below what was measured; the measured number falls inside the stated range.
By their numbers in this assay, from the lowest: compounds 2 and 3 (each within the scatter of the next); then compound 1.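

On the saturated ring carbon, the whole aromatic group can change in this assay with no step beyond the scatter: a 1.2-fold higher number from compound 2 to compound 3 (0.07 log units; within the scatter), with thiophen-2-yl, a five-membered aromatic ring, taking the place of 4-methoxyphenyl, a six-membered aromatic ring. The earlier step altered only a substituent on the six-membered ring, whereas this pair shows that a six-membered ring at this carbon is not needed to keep the value of compound 2 in this assay, and the exchange for 4-fluorophenyl gives a 2.5-fold lower number from compound 1 to compound 3 (0.40 log units; beyond the scatter), leaving compound 1 with the highest number of the three. No available evidence accounts for either step.

On these data alone, all three compounds keep an aromatic ring at this carbon, so it remains open how a non-aromatic group such as cyclohexyl or an aminomethyl chain would read here. Also open, as far as these compounds go, is whether a carboxylic acid on the aromatic ring would move the number further than methoxy or fluoro.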